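This account rests on a few compounds, and the source may have more. Where it says the series, first, only, none or still open, it means among the compounds named here.

Measured in an ADME assay on HepG2 cells (Homo sapiens) for cytotoxicity, with a stated time of 3 days; on this read-out higher numbers stand for lower toxicity in this test and lower numbers for higher toxicity in this test:
- compound 1 `O=C(CCSc1nnc(-c2ccncc2)s1)Nc1ccc(Cl)cc1`: 7260 nM
- compound 2 `O=C(CCSc1nnc(-c2ccncc2)s1)NCc1ccccc1Cl`: > 50000 nM, a limit

Compound 2 has no exact number in this assay; it stands at the limit of > 50000 nM in this assay, at which 1 of the 2 values shown sits. The next structure, compound 3 `O=C(CCSc1nnc(-c2ccncc2)s1)NCc1ccc(Cl)cc1`, differs from it as follows: 4-chlorophenyl in place of 2-chlorophenyl on a saturated chain carbon bound to an amide-type nitrogen. In words, this is 4-chlorophenyl in place of 2-chlorophenyl on a saturated chain carbon bound to an amide-type nitrogen.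

For the measured compounds named here, one measured step bears on this change: an at least 6.8-fold higher number from compound 1 to compound 2 (0.83 log units; beyond the scatter). That step is itself bounded by a limit and alters the group on the nitrogen in a different way, so it gives only loose guidance. Compound 3 shares its chlorinated ring position with compound 1 and its chain carbon with compound 2, so a lower number than the limit is expected, though perhaps not a large move. The expected change is an at least 1.5-fold lower number from compound 2 to compound 3 (0.19 log units; that floor lies within the scatter). For compound 3 the estimated value is 32000 nM, with an expected range from 11000 nM to 50000 nM.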

Compound 3, half-maximal cytotoxic concentration: 15600 nM
The estimate for compound 3 lay 2.1-fold (0.31 log units) above the measured number; the range from low to high includes it.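

In this assay, the chain carbon on the nitrogen does not by itself decide the outcome: with that carbon kept, 4-chlorophenyl in place of 2-chlorophenyl gives an at least 3.2-fold lower number from compound 2 to compound 3 (0.50 log units; beyond the scatter). The earlier step had changed the chlorine position and the chain carbon together, whereas the direct comparison of the 4-chlorinated pair now gives a 2.1-fold higher number from compound 1 to compound 3 (0.33 log units; beyond the scatter), so 4-chlorobenzyl and 4-chlorophenyl can be told apart in this test. The value of compound 2 is a limit, not a number, so the full size of the step to compound 3 stays unknown: the limit of > 50000 nM in this assay, at which 1 of the 3 values shown sits.

The compounds shown leave open how an unsubstituted benzyl group or a phenylethyl chain would read in this assay. They also leave open whether a fluorine or a methoxy group in place of the chlorine would follow the same course.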